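Hydroxymethyl to Carboxy on the Chain of Compound 3

The source may hold more compounds than are shown below. What is called first, only, known or untested is meant among the compounds shown, and "the series" means these compounds.

Compound 3 `O=c1c2ccccc2c(-c2cccnc2)nn1CCO` gives 69% in an assay on isolated protein (Oryctolagus cuniculus) with Thromboxane-A synthase (Homo sapiens) as the target, tested at 1 uM (a higher number here means more inhibition at the concentration tested (going by the name of the read-out), a lower number less inhibition), second highest of three measured values: compound 1 `CC(C)=CCn1nc(-c2cccnc2)c2ccccc2c1=O` gives 94%, while compound 2 `CCOC(=O)Cn1nc(-c2cccnc2)c2ccccc2c1=O` gives 28%. Compound 4 `O=C(O)Cn1nc(-c2cccnc2)c2ccccc2c1=O` differs from compound 3 by carboxy in place of hydroxymethyl on a saturated chain carbon bound to an aromatic nitrogen. The most relevant measured step is a number 41 percentage points higher from compound 2 to compound 3 (beyond the scatter), since compound 2 carries ethoxycarbonyl at the same place; a number 66 percentage points lower from compound 1 to compound 2 (beyond the scatter) and a number 25 percentage points lower from compound 1 to compound 3 (beyond the scatter) show that both chain changes from compound 1 lower inhibition, the ethoxycarbonyl one far more. A carboxy group at this position is therefore expected to move compound 4 toward the value of compound 2, an expected step of a number 29 percentage points lower from compound 3 to compound 4 (beyond the scatter). Compound 4 is estimated at 40%, in a range from 15% to 68%.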

Compound 4, a percentage reported as inhibition, at one concentration (the size of the read-out at that concentration, not a potency): 13%
The estimate for compound 4 lay 27 percentage points above the measured number; measured number outside the range, below it.
By their numbers in this assay, from the lowest: compound 4; then compound 2; then compound 3; then compound 1.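

Carboxy gives the lowest inhibition of the four chain ends in this assay, with large drops from the two compounds higher up (a number 56 percentage points lower from compound 3 to compound 4 (beyond the scatter); a number 81 percentage points lower from compound 1 to compound 4 (beyond the scatter)). Removing the ethyl from the ester does not recover inhibition but lowers it further (a number 15 percentage points lower from compound 2 to compound 4 (beyond the scatter)), so the loss seen with ethoxycarbonyl does not depend on the ethyl. Nothing measured here accounts for this order. The compounds shown leave open how an amide or an amine at this place would behave, and whether a longer chain carrying the carboxy would recover inhibition.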